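Swapping the ring-nitrogen aryl group: 3-chlorophenyl to 2,3-dimethylphenyl

The compounds below may be only part of what the source reports. "The series", "measured", "known", "first", "only" and "open" are said of these compounds alone.

Of the compounds shown here, three sharing one core have been tested in a functional assay for inhibition, using microsomes, tested at 100 ug/mL; on this read-out higher numbers stand for a weaker effect at the one concentration tested and lower numbers for a stronger effect. Compound 1, `COC(=O)C1=C(C)N(c2ccc(OC)cc2)C=C(C)C1c1ccccc1`, gives -14.7%. Compound 2, `COC(=O)C1=C(C)N(c2ccccc2)C=C(C)C1c1ccccc1`, gives -22.7%. Compound 3, `COC(=O)C1=C(C)N(c2cccc(Cl)c2)C=C(C)C1c1ccccc1`, gives -16.2%. Compound 3 thus sits between the other two, and each gap is within the scatter: a number 1.5 percentage points lower from compound 1 to compound 3 (within the scatter), and a number 6.5 percentage points higher from compound 2 to compound 3 (within the scatter). The remaining pair also changes little, since a number 8 percentage points lower from compound 1 to compound 2 (within the scatter).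

Compound 4, `COC(=O)C1=C(C)N(c2cccc(C)c2C)C=C(C)C1c1ccccc1`, differs from compound 3 only in the group on the ring nitrogen: 2,3-dimethylphenyl in place of 3-chlorophenyl on an amine nitrogen in a ring. The step that bears most directly on this change is the one where the same aryl group was exchanged, from compound 1 to compound 3, and it was within the scatter; the two steps that alter a single substituent on that aryl ring were within the scatter as well. No step beyond the scatter has been seen for any change at this position, so none is expected here either. Compound 4 is therefore estimated at -17%, between -32% and -2%, which means an expected step of a number 0.8 percentage points lower from compound 3 to compound 4 (within the scatter) in this assay.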

Compound 4, a percentage reported as activity, at one concentration (the size of the read-out at that concentration, not a potency): -22.7%
Estimate against measurement, compound 4: 5.7 percentage points above; the range from low to high includes it.
By their numbers in this assay, from the lowest: compounds 2, 4, 3 and 1 (each within the scatter of the next).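

In this assay, among the compounds shown here, the 2,3-dimethylphenyl group, the only aryl group here with more than one substituent, stays within the scatter of each group it is compared with: 3-chlorophenyl (a number 6.5 percentage points lower from compound 3 to compound 4 (within the scatter)), phenyl (no change at the digits printed from compound 2 to compound 4 (within the scatter)) and 4-methoxyphenyl (a number 8 percentage points lower from compound 1 to compound 4 (within the scatter)). These four aryl groups on the ring nitrogen therefore cannot be told apart on this read-out at the one concentration tested, even with a second substituent on the ring. Nothing measured here offers an explanation for this result.

Going by these compounds, whether an aryl ring bearing an amine or a carboxylic acid, or a longer alkyl chain in place of the aryl ring, would give a step beyond the scatter remains open. On these data alone, it is also open whether changing the methoxycarbonyl or phenyl group on the shared core would matter more on this read-out.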